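Cyclohexyl to 4-Methylphenyl on a Ring Amine Nitrogen

This account rests on a few compounds, and the source may have more. Where it says the series, first, only, none or still open, it means among the compounds named here.

Compound 1 `Nc1ccccc1NC(=O)c1ccc(CSC(=S)N2CCN(C3CCCCC3)CC2)cc1` was tested in a functional assay on MGC-803 cells (Homo sapiens) for antiproliferative activity, read by CCK-8 assay, with a stated time of 72 h, tested at 8 uM (a higher number here means a stronger effect of the compound at the concentration tested, a lower number a weaker effect), where compound 1 gives 75.3%. Among the two measured compounds it holds the higher number: compound 2 `Nc1ccccc1NC(=O)c1ccc(CSC(=S)N2CCc3ccc([N+](=O)[O-])cc32)cc1` gives 39.6% in this assay, a gap beyond the scatter. Compound 3 `Cc1ccc(N2CCN(C(=S)SCc3ccc(C(=O)Nc4ccccc4N)cc3)CC2)cc1` awaits measurement; it differs from compound 1 by 4-methylphenyl in place of cyclohexyl on an amine nitrogen in a ring. Within the data shown here, no measured pair shows this change, so the outlook rests on compound 1 alone. A modest downward step is expected, a number 13.3 percentage points lower from compound 1 to compound 3 (beyond the scatter). In this assay compound 3 is estimated at 62%, expected between 40% and 80%.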

Compound 3, a percentage reported as inhibition, at one concentration (the size of the read-out at that concentration, not a potency): 19.8%
Compound 3: the middle estimate sits 42.2 percentage points above what was measured; measured number below the stated range.
By their numbers in this assay, from the lowest: compound 3; then compound 2; then compound 1.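

Among these compounds, this pair gives the first direct reading of the amine nitrogen in the six-membered ring with two nitrogens: in this assay there is a number 55.5 percentage points lower from compound 1 to compound 3 (beyond the scatter) when 4-methylphenyl takes the place of cyclohexyl, so this position is far from indifferent to the group it carries. Cyclohexyl is clearly preferred over 4-methylphenyl here, although both groups are six-membered carbon rings. No measurement shown explains this drop. From the compounds shown here alone, it remains open whether the loss follows the aromatic ring itself or its methyl group, which a plain phenyl would separate. Whether a small methyl or an open butyl chain on this nitrogen would keep the number of compound 1 is also unanswered.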